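The compounds below may be only part of what the source reports. "The series", "measured", "known", "first", "only" and "open" are said of these compounds alone.

In an ADME assay on microsomes from liver (Mus musculus, strain CD1) for metabolic stability, read by LC-MS, with a stated time of 1 h (on this read-out higher numbers stand for a more stable compound and lower numbers for a less stable compound), compound 3 (`N#Cc1ccc(-c2ccc(CO[C@@H]3COc4nc([N+](=O)[O-])cn4C3)cc2)cc1`) gives 58% and compound 2 (`O=[N+]([O-])c1cn2c(n1)OC[C@@H](OCc1ccc(-c3cccc(OCc4ccccc4)c3)cc1)C2`) gives 50% so these two lie within the usual scatter of each other. Compound 1 (`CCOc1ccccc1-c1ccc(CO[C@@H]2COc3nc([N+](=O)[O-])cn3C2)cc1`) gives 0.2% and sits far under compound 3, well beyond the scatter.

Compound 4 (`O=[N+]([O-])c1cn2c(n1)OC[C@@H](OCc1ccc(-c3ccc(OC(F)(F)F)cc3)cc1)C2`) differs from compound 3 by a single change (trifluoromethoxy in place of cyano on an aromatic carbon), trifluoromethoxy in place of cyano on an aromatic carbon, para to a large group. For the measured compounds named here, only one measured step bears on it. That step, a number 57.8 percentage points higher from compound 1 to compound 3 (beyond the scatter) in this assay is large and shows that an exchange on an aromatic carbon can move the number a long way in this series. However, it swaps a whole 2-ethoxyphenyl group for 4-cyanophenyl, and a single step gives no direction for the present exchange. Going by the values given here, no measured compound carries trifluoromethoxy.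

The expected outcome is therefore a small move, with a number 6 percentage points lower from compound 3 to compound 4 (within the scatter) as the estimated step, within the scatter, although a larger move in either direction cannot be ruled out. For compound 4 the estimate is 52% with an expected range from 22% to 80% as the span of likely results.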

Compound 4, percent of the compound remaining: 96%
For compound 4 the middle estimate is 44 percentage points below the measured one; measured number outside the range, above it.
By their numbers in this assay, from the lowest: compound 1; then compounds 2 and 3 (each within the scatter of the next); then compound 4.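

In this assay, the exchange of cyano for trifluoromethoxy on an aromatic carbon, para to a large group, gives a number 38 percentage points higher from compound 3 to compound 4 (beyond the scatter). The earlier step at this part of the molecule swapped a whole 2-ethoxyphenyl group for 4-cyanophenyl, whereas this one changes only the group on the ring, so it shows that this position alone can move the number a long way and that, for this exchange, the move is upward. Nothing measured on these compounds accounts for the rise, and no explanation can be given for it.

The compounds shown leave open whether the rise is particular to trifluoromethoxy or would also be seen with other groups in the same place, such as a methoxy group, a trifluoromethyl group or an amine, as only cyano and trifluoromethoxy can be compared there. For the compounds shown here, they also leave open whether the same exchange would produce a step of similar size on a different core, as this single pair is the only direct comparison of the two groups.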